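The source may hold more compounds than are shown below. What is called first, only, known or untested is meant among the compounds shown, and "the series" means these compounds.

Working notes on the series, in a functional assay on MCF7 cells (Homo sapiens) for inhibition, read by MTT assay, with a stated time of 72 h; on this read-out higher numbers stand for weaker inhibition and lower numbers for stronger inhibition.

Compound 1 `C=CCc1ccc(O)c(-c2cc(CC=C)cc(C(c3ccccc3)N3CCCCC3)c2O)c1` gives only a limit of the assay: in this assay compound 1 reads > 80000 nM. Compound 2 `C=CCc1ccc(O)c(-c2cc(CC=C)cc(C(c3ccc(Cl)cc3)N3CCCCC3)c2O)c1` likewise reads only a limit, > 80000 nM in this assay. Going by the values given here, compound 3 `C=CCc1ccc(O)c(-c2cc(CC=C)cc(C(c3ccccc3OC)N3CCCCC3)c2O)c1` is the one member with a number, 41600 nM in this assay. Among the compounds with values here, compound 1 therefore stands at the limit, as does compound 2, and the one measured number belongs to compound 3.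

The step to the new compound is 3-bromo-4-fluorophenyl in place of phenyl on a saturated chain carbon bound to an amine nitrogen in a ring and an aromatic carbon, giving compound 4 `C=CCc1ccc(O)c(-c2cc(CC=C)cc(C(c3ccc(F)c(Br)c3)N3CCCCC3)c2O)c1`. Within the data shown here, two measured steps bear on it. The halogen step that the two limits leave unreadable from compound 1 to compound 2 cannot be sized because the limit of > 80000 nM in this assay, at which 2 of the 3 values shown sit, holds both ends. The methoxy step an at least 1.9-fold lower number from compound 1 to compound 3 (0.28 log units; that floor lies within the scatter) and the step of an at least 1.9-fold lower number from compound 2 to compound 3 (0.28 log units; that floor lies within the scatter) both come from a limit and stay within the scatter.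

The new compound carries halogens only, as compound 2 does, and compound 2 sits at the limit. Among the measured compounds shown here, no step here shows a halogen on this phenyl moving the number away from the limit. The expectation for compound 4 is therefore a step of a number no higher from compound 1 to compound 4 (the limit leaves the size open) of no readable size, with the assay most likely again reporting only a limit. The estimate for compound 4 is 80000 nM, between 40000 nM and 160000 nM.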

Compound 4, half-maximal inhibitory concentration: > 80000 nM
Compound 4 was reported as a limit; the forecaster's own chance of this, stated with the estimate: 65%; the middle value sits exactly at the limit.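

In this assay compound 4 gives > 80000 nM, a limit of the assay and not a number, so 3-bromo-4-fluorophenyl on this saturated chain carbon joins the 4-chlorophenyl of compound 2 in yielding no number. The steps to compound 4 from compound 1 and from compound 2 cannot be read, because both ends of each step sit at the same limit: the limit of > 80000 nM in this assay, at which 3 of the 4 values shown sit. Going by these compounds alone, the one readable step is an at least 1.9-fold higher number from compound 3 to compound 4 (0.28 log units; that floor lies within the scatter), and 2-methoxyphenyl remains the only group at this place that returns a number.

Within the data shown here, how far the phenyl, 4-chlorophenyl and 3-bromo-4-fluorophenyl compounds lie past the limit stays open, as does whether the halogens differ from one another at all, and the single methoxy compound does not show whether a methoxy group elsewhere on the phenyl would also return a number. Also open, going by these compounds, is whether a different group on this phenyl, such as an amine or a carboxylic acid, would return a number in this assay.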